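Quinazoline series: carboxy to 2-hydroxyethyl on the pyrazole chain

The source may report more compounds than this note shows. Statements on the series, on what has been measured and on what is new or still open speak of the compounds shown alone.

Of the compounds shown here, two of the shared core carry numbers so far. Compound 1 `COc1ncc(-c2ccc3ncnc(Nc4ccc(OCCO)cc4)c3c2)cc1NS(C)(=O)=O` gives 3270 nM in a functional assay on MCF7 cells (Homo sapiens) for antiproliferative activity, read by sulforhodamine B assay, with a stated time of 72 h; a lower number here means a stronger inhibitor, a higher number a weaker inhibitor. Compound 2 `COc1ncc(-c2ccc3ncnc(Nc4cnn(CC(=O)O)c4)c3c2)cc1NS(=O)(=O)c1ccc(F)cc1F` gives 700 nM in this assay, the lower of the two numbers; compound 1 stands higher, and that gap is beyond the usual scatter. Compound 3 `COc1ncc(-c2ccc3ncnc(Nc4cnn(CCCO)c4)c3c2)cc1NS(=O)(=O)c1ccc(F)cc1F` is not yet measured. It differs from compound 2 in one place: 2-hydroxyethyl in place of carboxy on a saturated chain carbon bound to an aromatic nitrogen. Within the data shown here, no pair of measured compounds isolates this change, so its effect has no direct precedent. The expected step from compound 2 to compound 3 in this assay is a modest one toward a lower number, a 1.6-fold lower number from compound 2 to compound 3 (0.19 log units; within the scatter), not far outside the scatter. On that basis compound 3 is estimated at 450 nM in this assay, with a range from 150 nM to 1400 nM.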

Compound 3, half-maximal inhibitory concentration: 1310 nM
Beside the measured number, compound 3's estimate is 2.9-fold (0.46 log units) below it; the measured number falls inside the stated range.
By their numbers in this assay, from the lowest: compounds 2 and 3 (each within the scatter of the next); then compound 1.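

Among these compounds, this is the first one-place step: in this assay, 2-hydroxyethyl in place of carboxy on a saturated chain carbon bound to an aromatic nitrogen gives a 1.9-fold higher number from compound 2 to compound 3 (0.27 log units; within the scatter) and thus no separation between the two groups. At this position, a group with no carboxy can therefore stand in the shared core without a step beyond the scatter, although this rests on a single pair. No measurement shown here accounts for the size of this step.

Read one bond further out, the change is carboxymethyl to 3-hydroxypropyl, so chain length and end group change together and their separate contributions remain unresolved. Also open, on these data alone, is how an amine or a primary amide at the chain end, or a longer chain carrying a hydroxyl, would read in this assay on this same core.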